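Adding a Methoxy Group to Compound 3

The compounds below may be only part of what the source reports. "The series", "measured", "known", "first", "only" and "open" are said of these compounds alone.

Compound 3 `N#C/C(=C\c1ccccc1)C(=O)NCc1ccc(Cl)c(Cl)c1` was tested in a functional assay on MIA cells (Homo sapiens) for inhibition, read by MTT assay, with a stated time of 72 h (a lower number here means a stronger inhibitor of growth, a higher number a weaker inhibitor of growth), where compound 3 gives 47000 nM. Of the two compounds with a definite number, compound 3 has the higher one; its nearest neighbour, compound 2 `COc1ccc(CNC(=O)/C(C#N)=C/c2ccc(Cl)cc2)cc1`, gives 16000 nM, and that gap lies beyond the usual scatter. Compound 1 `N#C/C(=C\c1ccc[nH]1)C(=O)NCc1ccc(Cl)c(Cl)c1` gives only a limit of the assay, > 50000 nM, and not a number. Within the data shown here, the single measured step on the double-bonded chain side of the shared core, an at least 1.0-fold lower number from compound 1 to compound 3 (0.02 log units; that floor lies within the scatter), stays within the scatter.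

Compound 4 `COc1ccc(/C=C(\C#N)C(=O)NCc2ccc(Cl)c(Cl)c2)cc1` differs from compound 3 by methoxy in place of hydrogen on an aromatic carbon. Among the measured compounds shown here, no measured step adds a methoxy group to this ring, so this change has no direct precedent. For the measured compounds named here, compound 2 carries its methoxy on the other ring and its chlorine in a different arrangement, so its value shows only that a compound of this family can sit well below compound 3. Going by the values given here, with the within-scatter change on the same ring as the only guide, no movement beyond the scatter is expected. The estimated step is a 1.2-fold lower number from compound 3 to compound 4 (0.07 log units; within the scatter). Compound 4 is therefore expected at 40000 nM, within 15000 nM to 100000 nM, with a real chance of a limit rather than a number.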

Compound 4, concentration for 50% growth inhibition: 79000 nM
Beside the measured number, compound 4's estimate is 2.0-fold (0.30 log units) below it; low and high end bracket the measured number.
By their numbers in this assay, from the lowest: compound 2; then compounds 3 and 4 (each within the scatter of the next).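

In this assay, the phenyl to 4-methoxyphenyl change now has a direct measurement, a 1.7-fold higher number from compound 3 to compound 4 (0.23 log units; within the scatter), and this step stays within the scatter. Among these compounds, until now, no measured step had added a methoxy group to this ring, so this is the first sign that methoxy in place of hydrogen, on this aromatic carbon para to a large group, gives a value that cannot be told apart from that of the unsubstituted ring. The step from compound 1 to compound 4 cannot be read, because compound 1 gives a limit and not a number: the limit of > 50000 nM in this assay, at which 1 of the 4 values shown sits.

On these data alone, a single substitution at a single place cannot show whether this carbon is insensitive to change in general, so it remains open whether an amine, a carboxylic acid or a longer chain, such as butoxy, in place of the hydrogen would shift the number beyond the scatter. As far as these compounds go, it is also open whether a methoxy group on another carbon of this ring, or the same methoxy group on a different amide side of the shared core, would behave as it does in compound 4.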